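A few compounds are considered here, and "the series" means these few. Any claim that something is new, unique, unknown or untested is made for them only; others in the source may bear on it.

In a functional assay on U-87MG ATCC cells (Homo sapiens) for antiproliferative activity, with a stated time of 3 days (a higher number here means that more compound is needed for the effect, a lower number that less compound is needed), compound 1 `Oc1ccc(CN(Cc2cccc(C(F)(F)F)c2)Cc2ccc(O)c3ncccc23)c2cccnc12` gives 2 uM and compound 2 `Oc1ccc(CN(Cc2cccc(I)c2)Cc2ccc(O)c3ncccc23)c2cccnc12` gives 2 uM, so compound 2 stands level with compound 1. Compound 3 `Oc1ccc(CN(Cc2cccs2)Cc2ccc(O)c3ncccc23)c2cccnc12` carries thiophen-2-yl in place of 3-iodophenyl on a saturated chain carbon bound to an amine nitrogen. Within the data shown here, the only measured step that bears on this is no change at the digits printed from compound 1 to compound 2 (within the scatter), where iodo replaced trifluoromethyl on an aromatic carbon. Among the measured compounds shown here, no measured step covers the exchange of a whole ring, so this guide is weak. The expected step in this assay is a 1.3-fold higher number from compound 2 to compound 3 (0.10 log units; within the scatter), nothing beyond the scatter. For compound 3 the estimate is 2.5 uM, with an expected range of 1 uM to 6 uM.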

Compound 3, concentration for half-maximal effect: < 0.2 uM
Compound 3: no number, only a limit; the forecaster's own chance of this, stated with the estimate: 3%; middle value at least 12-fold (1.09 log units) from the limit.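

Exchanging iodo for trifluoromethyl on an aromatic carbon had left the number unchanged, but replacing the whole ring on this saturated chain carbon bound to an amine nitrogen moves it clearly in this assay. Thiophen-2-yl in place of 3-iodophenyl gives an at least 10-fold lower number from compound 2 to compound 3 (1.00 log units; beyond the scatter), and in place of 3-(trifluoromethyl)phenyl it gives an at least 10-fold lower number from compound 1 to compound 3 (1.00 log units; beyond the scatter). Compound 3 stands at a limit, not a number: the limit of < 0.2 uM in this assay, at which 1 of the 3 values shown sits.

The ring size and the sulfur atom change together here, so the compounds shown cannot separate them. From the compounds shown here alone, whether unsubstituted phenyl or furan-2-yl at this place would give a similar step remains open.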